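A few compounds are considered here, and "the series" means these few. Any claim that something is new, unique, unknown or untested is made for them only; others in the source may bear on it.

Compound 1 `FC(F)(F)c1cccnc1N1CCC(NC(=S)Nc2cccnc2)CC1` was tested in an assay on membranes from brain for binding affinity to Lysophosphatidylserine lipase ABHD12 (Mus musculus), read by fluorescence, with a stated time of 20 min; a lower number here means a stronger inhibitor, a higher number a weaker inhibitor. In this assay compound 1 gives > 5000 nM, which is a limit of the assay and not a number. Compound 2 `S=C(Nc1cccnc1)NC1CCN(c2ncccc2Cl)CC1` gives > 5000 nM in this assay, again a limit. The step that the two limits leave unreadable from compound 1 to compound 2 therefore cannot be sized, because of the limit of > 5000 nM in this assay, at which 2 of the 2 values shown sit. Compound 3 `FC(F)(F)Oc1ccc(Oc2ccnc(N3CCC(NC(=S)Nc4cccnc4)CC3)c2C(F)(F)F)cc1` carries 4-(trifluoromethoxy)phenoxy in place of hydrogen on an aromatic carbon. Within the data shown here, no measured step covers this change, and the single step on record is unreadable, so its direction is open. Compound 3 is expected to give about 6000 nM, with a range from 800 nM to 30000 nM. The expected step that the limit leaves unreadable from compound 1 to compound 3 thus remains uncertain.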

Compound 3, half-maximal inhibitory concentration: 2800 nM
Estimate against measurement, compound 3: 2.1-fold (0.33 log units) above, within the range that was stated.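

Compound 3 is the first compound shown to give a number rather than a limit in this assay, so this position, opposite the ring nitrogen, accepts the large 4-(trifluoromethoxy)phenoxy group with measurable inhibition. The change gives an at least 1.7-fold lower number from compound 1 to compound 3 (0.25 log units; that floor lies within the scatter). That figure is only a floor, and the true step cannot be sized because compound 1 stands at a limit: the limit of > 5000 nM in this assay, at which 2 of the 3 values shown sit.

As far as these compounds go, it remains open whether the phenoxy ring alone or its trifluoromethoxy group accounts for this result. From the compounds shown here alone, the effect of a plain methoxy group or an amine at this carbon also remains open.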